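A few compounds are considered here, and "the series" means these few. Any claim that something is new, unique, unknown or untested is made for them only; others in the source may bear on it.

Measured compounds:
- Compound 1, `C=C(C)C(=O)N(Cc1ccc(OC)c(O)c1)c1cc(OC)c(OC)c(OC)c1`: 390 nM
- Compound 2, `C/C=C/C(=O)N(Cc1ccc(OC)cc1)c1cc(OC)c(OC)c(OC)c1`: 450 nM

Of the compounds shown here, two have been measured in a functional assay on MGC-803 cells (Homo sapiens) for inhibition, read by MTT assay, with a stated time of 48 h; on this read-out lower numbers stand for stronger inhibition and higher numbers for weaker inhibition. Compound 1 gives 390 nM, which is the lower of the two numbers in hand, and compound 2 gives 450 nM; the two values lie within the scatter of each other, so nothing can be said about an order between them. The two compounds also differ in more than one part of the structure, so no single step can be read from them.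

Compound 3, `COc1ccc(CN(C(=O)/C=C/CBr)c2cc(OC)c(OC)c(OC)c2)cc1O`, has not yet been measured. It is derived from compound 1 by a single change at the carbonyl carbon of the amide: 3-bromoprop-1-en-1-yl in place of 1-methylethenyl on a carbonyl carbon

Going by the values given here, no measured pair in this set isolates this kind of change, so there is no reference step to lean on. On the basis of the values of compound 1 and compound 2, which show that the amide substituent can vary without moving the number beyond the scatter, the expected step is a 1.3-fold higher number from compound 1 to compound 3 (0.11 log units; within the scatter), that is, no change beyond the usual scatter in this assay. Compound 3 is therefore estimated to give 500 nM, with a plausible range from 170 nM to 1500 nM.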

Compound 3, half-maximal inhibitory concentration: 71 nM
For compound 3 the middle estimate is 7.0-fold (0.85 log units) above the measured one; measured number outside the range, below it.
By their numbers in this assay, from the lowest: compound 3; then compounds 1 and 2 (each within the scatter of the next).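

In this assay, the carbonyl carbon of the amide proves to be a place where one change of substituent moves the number beyond the scatter: 3-bromoprop-1-en-1-yl in place of 1-methylethenyl gives a 5.5-fold lower number from compound 1 to compound 3 (0.74 log units; beyond the scatter) with the rest of compound 1 unchanged. Compound 1 and compound 2 could not show this, as they differ in more than one part of the structure and their values lie within the scatter of each other, whereas this pair isolates the substituent on the carbonyl carbon. Nothing among the data on hand speaks to what lies behind this step, so it stands as an observation only.

The compounds shown leave open whether the step belongs to the bromine or to the rest of the chain: a plain prop-1-en-1-yl group, or a chlorine or an amine in the place of the bromine, on the core of compound 1 would separate the two. They also leave open whether the same change would give a step of similar size on the core of compound 2.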